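This account rests on a few compounds, and the source may have more. Where it says the series, first, only, none or still open, it means among the compounds named here.

In an ADME assay on Vero cells (Chlorocebus sabaeus) for inhibition, read by sulforhodamine B assay, with a stated time of 48 h (a lower number here means a stronger inhibitor of growth, a higher number a weaker inhibitor of growth), compound 1 `O=C(NNC(=O)c1ccc2[nH]c(-c3ccc([N+](=O)[O-])o3)nc2c1)c1ccccc1` gives 31.3 ug/mL. Compound 2 `COc1cc(C(=O)NNC(=O)c2ccc3[nH]c(-c4ccc([N+](=O)[O-])s4)nc3c2)cc(OC)c1OC` gives 31.3 ug/mL, so the two stand level at the digits shown. They differ in more than one place, so no single structural change has a measured size yet. Compound 3 `O=CNNC(=O)c1ccc2[nH]c(-c3ccc([N+](=O)[O-])o3)nc2c1` still awaits its measurement in this assay. It departs from compound 1 in one place: hydrogen in place of phenyl on a carbonyl carbon. Put simply, hydrogen stands in place of phenyl on a carbonyl carbon, which turns benzoyl into formyl. Within the data shown here, a whole ring goes, which looks large on paper, but no measured pair shows what this particular change does to growth inhibition. The one hint is that, though built differently from compound 1, compound 2 also reads 31.3 ug/mL. No move beyond the scatter is therefore expected in this assay, and neither direction is favoured, so the expected step is no change at the digits printed from compound 1 to compound 3 (within the scatter). Among the measured compounds shown here, for compound 3 the estimated value is 31.3 ug/mL, with an expected range from 12 ug/mL to 100 ug/mL, kept wide as only two measured compounds support it.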

Compound 3, concentration for 50% growth inhibition: 62.5 ug/mL
Estimate against measurement, compound 3: 2.0-fold (0.30 log units) below, within the range that was stated.
By their numbers in this assay, from the lowest: compounds 1, 2 and 3 (each within the scatter of the next).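

In this assay, among these compounds, the loss of a whole phenyl ring from the carbonyl carbon, which turns benzoyl into formyl, gives a 2.0-fold higher number from compound 1 to compound 3 (0.30 log units; within the scatter) and provides the first measured step at this position. On the core of compound 1, then, a ring can give way to a single hydrogen atom without a move beyond the usual scatter of repeated measurements, although this rests on one pair of compounds. Nothing measured here offers an explanation for this result.

Phenyl and hydrogen are only two possible groups at this carbonyl carbon, so it remains open whether an ethyl chain, a longer alkyl chain, an amine or a group carrying a carboxylic acid would also stay within the scatter. On these data alone, it also remains open whether the same replacement of the ring by hydrogen would read the same way on the core of compound 2.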